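The source may report more compounds than this note shows. Statements on the series, on what has been measured and on what is new or still open speak of the compounds shown alone.

Measured so far:
Compound 1 `COc1ccc(OC(=O)c2cn(-c3ccccc3)nc2-c2cccnc2)cc1`; in a functional assay on MDA-MB-231 cells (Homo sapiens) for cytotoxicity, read by MTT assay, with a stated time of 48 h (a higher number here means a weaker inhibitor, a lower number a stronger inhibitor), compound 1 gives > 100000 nM, a limit of the assay.
Compound 2 `Cc1ccc(C(C)C)c(OC(=O)c2cn(-c3ccccc3)nc2-c2cccnc2)c1`; in this assay compound 2 gives > 100000 nM, again a limit.
Compound 3 `COc1ccc(OC(=O)c2cn(-c3ccccc3)nc2-c2ccncc2)cc1`; in this assay compound 3 gives > 100000 nM, also a limit.

Compound 3 therefore stands only at a limit, and the two other values shown sit at the same limit (the limit of > 100000 nM in this assay, at which 3 of the 3 values shown sit). The two measured steps, a step that the two limits leave unreadable from compound 1 to compound 2 and a step that the two limits leave unreadable from compound 1 to compound 3, are both unreadable, since each runs from one limit to another; the first of them changes the group on the oxygen next to the carbonyl, the second the pyridyl on the aromatic carbon, and neither yields a readable size.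

Compound 4 `O=C(O)c1cn(-c2ccccc2)nc1-c1ccncc1` differs from compound 3 by hydrogen in place of 4-methoxyphenyl on an oxygen next to a carbonyl group. The step from compound 1 to compound 2 bears on the same oxygen but gives no size. With every value shown at the limit, the estimated step that the limit leaves unreadable from compound 3 to compound 4 is expected to show no reading beyond the scatter. Compound 4 is estimated in this assay at 150000 nM, within 50000 nM to 1000000 nM, most likely reported as a limit again.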

Compound 4, half-maximal inhibitory concentration: > 100000 nM
Compound 4: a limit, no number; the forecaster's own chance of this, stated with the estimate: 85%; the middle value lies beyond the limit too.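

No step can be read between compound 3 and compound 4, as both stand only at a limit in this assay: the limit of > 100000 nM in this assay, at which 4 of the 4 values shown sit.

The compounds shown leave open whether any change on the oxygen next to a carbonyl group, or of the pyridyl group, yields a measurable value in this assay.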